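Shortening the chain and moving the hydroxyl: compound 4

This account rests on a few compounds, and the source may have more. Where it says the series, first, only, none or still open, it means among the compounds named here.

Measured so far in a functional assay (Pituitary gland cell) with Rattus norvegicus as the target; on this read-out lower numbers stand for an effect already at smaller amounts and higher numbers for an effect only at larger amounts of compound:
compound 1 `CC(C)(CC(=O)N[C@@H]1CCc2ccccc2N(Cc2ccc(-c3ccccc3-c3nn[nH]n3)cc2)C1=O)NCCO` gives 30 nM
compound 2 `CC(C)[C@H](O)CNC(C)(C)CC(=O)N[C@@H]1CCc2ccccc2N(Cc2ccc(-c3ccccc3-c3nn[nH]n3)cc2)C1=O` gives 1000 nM
compound 3 `C[C@H](O)CNC(C)(C)C(=O)N[C@@H]1CCc2ccccc2N(Cc2ccc(-c3ccccc3-c3nn[nH]n3)cc2)C1=O` gives 700 nM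

Compound 2 stands highest of the three, though compound 3 sits within the scatter of it, and compound 1 lies far off: a 33-fold higher number from compound 1 to compound 2 (1.52 log units; beyond the scatter). Compound 4 `C[C@H](O)CCNC(C)(C)C(=O)N[C@@H]1CCc2ccccc2N(Cc2ccc(-c3ccccc3-c3nn[nH]n3)cc2)C1=O` is not yet measured. The change is 1-((3-hydroxybutyl)amino)-1-methylethyl in place of 2-((2-hydroxy-3-methylbutyl)amino)-2-methylpropyl on a carbonyl carbon. The closest guide is the step of a 1.4-fold lower number from compound 2 to compound 3 (0.15 log units; within the scatter), where a similar shortening to a 1-methylethyl link left the number essentially unchanged; the large steps of a 33-fold higher number from compound 1 to compound 2 (1.52 log units; beyond the scatter) and a 23-fold higher number from compound 1 to compound 3 (1.37 log units; beyond the scatter) both lead away from compound 1, which compound 4 does not resemble. No step beyond the scatter is therefore expected, a 1.7-fold lower number from compound 2 to compound 4 (0.22 log units; within the scatter). Compound 4 is expected to give about 600 nM, between 200 nM and 2000 nM.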

Compound 4, concentration for half-maximal effect: 50 nM
Beside the measured number, compound 4's estimate is 12-fold (1.08 log units) above it; the measured number lies below the stated range.
By their numbers in this assay, from the lowest: compounds 1 and 4 (each within the scatter of the next); then compounds 3 and 2 (each within the scatter of the next).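

In this assay the side chain on this carbonyl carbon reacts strongly to a small change: there is a 14-fold lower number from compound 3 to compound 4 (1.15 log units; beyond the scatter) when 2-hydroxypropyl replaces 1-hydroxyethyl on the saturated chain carbon bound to the amine nitrogen. The full side-chain exchange gives a 20-fold lower number from compound 2 to compound 4 (1.30 log units; beyond the scatter) and what remains is a 1.7-fold higher number from compound 1 to compound 4 (0.22 log units; within the scatter) so both the shorter and the longer link can carry a low number, though compound 2 and compound 3 show that neither does so with every hydroxyl-bearing chain.

Going by these compounds, whether a longer chain, or a carboxylic acid in place of the hydroxyl, would keep the number low stays open. Nothing available explains why moving the hydroxyl matters so much.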